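A few compounds are considered here, and "the series" means these few. Any claim that something is new, unique, unknown or untested is made for them only; others in the source may bear on it.

Three compounds have been measured in a functional assay on Huh-5-2 cells (Homo sapiens) for cytotoxicity, read by microscopy; on this read-out lower numbers stand for higher toxicity in this test and higher numbers for lower toxicity in this test:

compound 1 `CC(=O)OC[C@H]1O[C@@H](n2c(SCc3cc4cc(Br)ccc4oc3=O)nc3cncnc32)[C@H](O)[C@@H]1O` gives 31000 nM
compound 2 `CC(=O)OC[C@H]1O[C@@H](n2c(SCc3cc4cc(Br)cc(Br)c4oc3=O)nc3cncnc32)[C@H](O)[C@@H]1O` gives 7000 nM
compound 3 `Nc1ncnc2c1nc(SCc1cc3ccccc3oc1=O)n2[C@@H]1O[C@H](CO)[C@@H](O)[C@H]1O` gives 49000 nM

Compound 1 and compound 2 share one core and differ by bromo in place of hydrogen on an aromatic carbon. That change made a 4.4-fold lower number from compound 1 to compound 2 (0.65 log units; beyond the scatter). Compound 3 is built on a different core; the difference between the two cores is not broken down here. The values of compound 3 and compound 1 lie within the usual scatter of each other, while compound 3 and compound 2 stand clearly apart.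

Compound 4 `Nc1ncnc2c1nc(SCc1cc3cc(Br)ccc3oc1=O)n2[C@@H]1O[C@H](CO)[C@@H](O)[C@H]1O` has not yet been measured in this assay. It arises from compound 3 by bromo in place of hydrogen on an aromatic carbon. This is the same kind of change as from compound 1 to compound 2, but not the same: there the bromo entered ortho to a fused ring and meta to a bromo group, here it enters meta to a fused ring and para to a fused ring, with no bromo nearby. A lower number is expected for compound 4 because a 4.4-fold lower number from compound 1 to compound 2 (0.65 log units; beyond the scatter) went that way. Among the measured compounds shown here, the place is not the same and only one such step is known, so the step expected from compound 3 to compound 4 is taken as smaller, a 2.7-fold lower number from compound 3 to compound 4 (0.43 log units; beyond the scatter). Compound 4 is estimated at 18000 nM, between 7000 nM and 45000 nM.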

Compound 4, half-maximal cytotoxic concentration: 41000 nM
Compound 4: middle estimate off by 2.3-fold (0.36 log units), on the low side; measured number inside the range.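

On the core of compound 3, bromo in place of hydrogen on an aromatic carbon gives a 1.2-fold lower number from compound 3 to compound 4 (0.08 log units; within the scatter), so in this assay this step cannot be told apart from the ordinary spread of repeated measurements. The size of the earlier step therefore did not carry over to this core, and the two steps differ: the same change on two cores in this assay, a 4.4-fold lower number (0.65 log units; beyond the scatter) from compound 1 to compound 2 and a 1.2-fold lower number (0.08 log units; within the scatter) from compound 3 to compound 4, 3.7-fold (0.57 log units) apart, beyond the scatter of two such steps

This does not explain the gap, as the two steps differ in more than the core: the earlier one added a second bromo at another place on the ring, while the new one adds a first bromo, meta to a fused ring and para to a fused ring, and two steps alone make no rule for the series.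

Still open, as far as these compounds go, is whether a second bromo on compound 4 would lower the number as it did from compound 1 to compound 2, which would help separate the role of the core from that of the place. Also open, from the compounds shown here alone, is how an amine or a carboxylic acid at the same place would read in this assay.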